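Exchanging the (pyridin-3-yl)sulfonyl group of compound 1

The source may hold more compounds than are shown below. What is called first, only, known or untested is meant among the compounds shown, and "the series" means these compounds.

Within the data shown here, in a functional assay on VCaP cells (Homo sapiens) for antiproliferative activity, read by CCK-8 assay, with a stated time of 6 days (a lower number here means a stronger inhibitor, a higher number a weaker inhibitor), compound 1 (`C[C@@H](Cn1ccc(-c2ccc(C#N)c(Cl)c2)n1)NS(=O)(=O)c1cccnc1`) gives 2450 nM and holds the lower of the two numbers measured so far. Compound 2 (`C[C@@H](Cn1ccc(-c2cc(F)c(C#N)c(Cl)c2)n1)NC(=O)Nc1cc(C(C)(C)C)[nH]n1`) gives 5120 nM as the higher number, and the gap between them lies beyond the usual scatter. The two differ in more than one place, so that gap isolates no single change. Compound 3 (`Cc1ccnc(N[C@@H](C)Cn2ccc(-c3ccc(C#N)c(Cl)c3)n2)n1`), not yet measured, carries 4-methylpyrimidin-2-yl in place of (pyridin-3-yl)sulfonyl on an amine nitrogen. Among the measured compounds shown here, no measured pair shows this exchange, so the expectation stays anchored on compound 1 at 2450 nM and on little else. In this assay the expected step is a 1.2-fold lower number from compound 1 to compound 3 (0.09 log units; within the scatter) and it should stay within the scatter, with no firm direction. For compound 3 the estimate is 2000 nM with an expected range of 500 nM to 8000 nM once it is measured.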

Compound 3, half-maximal inhibitory concentration: 850 nM
The estimate for compound 3 lay 2.4-fold (0.37 log units) above the measured number; the measured number falls inside the stated range.
By their numbers in this assay, from the lowest: compound 3; then compound 1; then compound 2.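

In this assay, among these compounds, this is the first change at the amine nitrogen that can be read on its own, since the earlier pair differed in more than one place: a 2.9-fold lower number from compound 1 to compound 3 (0.46 log units; beyond the scatter), with 4-methylpyrimidin-2-yl in place of (pyridin-3-yl)sulfonyl. The sulfonyl group is therefore not required at this position, and an aromatic ring attached directly to the nitrogen gives a lower number, a step beyond the scatter. No measurement shown here accounts for this gain, so it stands only as an observation about this one exchange.

The compounds shown leave open whether the methyl group or the second ring nitrogen matters, which a plain pyrimidin-2-yl or a pyridin-2-yl group on this nitrogen could settle. Going by these compounds, how an acetyl or a benzyl group at the same place would compare also remains open.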